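The source may report more compounds than this note shows. Statements on the series, on what has been measured and on what is new or still open speak of the compounds shown alone.

Measured in an ADME assay (liver) for pharmacokinetics, with Liver microsome (Rattus norvegicus) as the target, using microsomes; on this read-out higher numbers stand for a longer-lived compound and lower numbers for a shorter-lived compound:
compound 1 `CCOc1cc(NC(=O)C2(NC(=O)c3ccc4c(C5CCCC5)c(-c5ncc(Cl)cn5)n(C)c4c3)CCC2)ccc1/C=C/C(=O)OC(=O)C[C@H](O)C(=O)O` gives 7.92 h;
compound 2 `CCOC(=O)/C=C/c1ccc(NC(=O)C2(NC(=O)c3ccc4c(C5CCCC5)c(-c5ncc(Cl)cn5)n(C)c4c3)CCC2)cc1OCC` gives 3.07 h.

Among the compounds with values here, compound 2 stands lowest of the two numbers; the only step, a 2.6-fold lower number from compound 1 to compound 2 (0.41 log units; beyond the scatter), is modest and beyond the scatter.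

Compound 3 `CCOc1cc(NC(=O)C2(NC(=O)c3ccc4c(C5CCCC5)c(-c5ncc(Cl)cn5)n(C)c4c3)CCC2)ccc1/C=C/C(=O)OCCOc1ccccc1` differs from compound 2 by phenoxy in place of hydrogen on a saturated chain carbon, two bonds along the chain from an oxygen next to a carbonyl group. Within the data shown here, no measured step covers this change; the one step present, from compound 1 to compound 2, alters the group on the oxygen itself and does not bear on growth two bonds further along the chain. Hence no direction can be read from it, and for compound 3 no step beyond the scatter is expected, a 1.1-fold higher number from compound 2 to compound 3 (0.04 log units; within the scatter). Compound 3 is estimated at 3.4 h, range 1.2 h to 9.5 h.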

Compound 3, half-life: 16.5 h
For compound 3 the middle estimate is 4.9-fold (0.69 log units) below the measured one; measured number outside the range, above it.
By their numbers in this assay, from the lowest: compound 2; then compound 1; then compound 3.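

In this assay phenoxy on this saturated chain carbon gives a 5.4-fold higher number from compound 2 to compound 3 (0.73 log units; beyond the scatter), the first sign that growth at this place can raise the half-life. Replacing (2-carboxy-2-hydroxyethyl)carbonyl with 2-phenoxyethyl on the same oxygen gives a 2.1-fold higher number from compound 1 to compound 3 (0.32 log units; beyond the scatter), so compound 3 now stands highest of the three. No evidence here speaks to the reason for either rise.

As far as these compounds go, it remains open whether the phenyl ring, the ether oxygen or the chain length carries the change. A 2-aminoethyl group, or a longer chain ending in phenoxy, would test this.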